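The source may report more compounds than this note shows. Statements on the series, on what has been measured and on what is new or still open speak of the compounds shown alone.

Compound 2 `O=C1NC2(CC2c2ccc3cccc(OCc4ccccc4)c3n2)C(=O)N1C1CCCCC1` gives 300 mg/kg in a functional assay on the whole organism (strain Kunming) with Mus musculus as the target, in the maximal electroshock model, with a stated time of 4 h (on this read-out lower numbers stand for an effect already at smaller amounts and higher numbers for an effect only at larger amounts of compound), and stands level with compound 1 `O=C1NC2(CC2c2ccc3cccc(OCc4ccccc4)c3n2)C(=O)N1c1ccccc1`, whose value in this assay is 300 mg/kg. Within the data shown here, the only measured step, no change at the digits printed from compound 1 to compound 2 (within the scatter), lies within the scatter. Compound 3 `CCC(CO)N1C(=O)NC2(CC2c2ccc3cccc(OCc4ccccc4)c3n2)C1=O` differs from compound 2 as follows: 1-(hydroxymethyl)propyl in place of cyclohexyl on an amide-type nitrogen in a ring. That single step is the only one that bears on this change, and it showed nothing beyond the scatter, so compound 3 is expected to show no step beyond the scatter either, no change at the digits printed from compound 2 to compound 3 (within the scatter). The estimate for compound 3 in this assay is therefore 300 mg/kg, within a range from 100 mg/kg to 600 mg/kg.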

Compound 3, minimum effective dose: 30 mg/kg
Compound 3: the middle estimate sits 10-fold (1.00 log units) above what was measured, outside the stated range (below it).
By their numbers in this assay, from the lowest: compound 3; then compounds 1 and 2 (each within the scatter of the next).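

At this position on the amide-type nitrogen in a ring, the earlier swap of phenyl for cyclohexyl had shown no movement, but in this assay 1-(hydroxymethyl)propyl gives a 10-fold lower number from compound 2 to compound 3 (1.00 log units; beyond the scatter) and a 10-fold lower number from compound 1 to compound 3 (1.00 log units; beyond the scatter). The position is therefore not indifferent to its substituent, and an open chain bearing a hydroxyl outperforms both ring groups here. No evidence is available that accounts for this step. The change removes the ring and adds the hydroxyl together, so their shares cannot be separated. As far as these compounds go, a 1-methylpropyl group, lacking the hydroxyl, or an amine in its place, remains open.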